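The source may hold more compounds than are shown below. What is called first, only, known or untested is meant among the compounds shown, and "the series" means these compounds.

Compound 3 `COc1cc(-c2nn(-c3cccc(NC(=O)Nc4ccc(Cl)c(C(F)(F)F)c4)c3)cc2-c2ccncc2)ccc1Cl` gives 1820 nM in a functional assay on NCI-H226 cells (Homo sapiens) for inhibition, read by sulforhodamine B assay, with a stated time of 48 h (a higher number here means a weaker inhibitor of growth, a lower number a stronger inhibitor of growth), the second highest of the three numbers: compound 2 `O=C(Nc1cccc(-n2cc(-c3ccncc3)c(-c3ccc(Cl)c(O)c3)n2)c1)Nc1ccc(Cl)c(Cl)c1`, with 1510 nM, lies within the scatter of it, while compound 1 `O=C(Nc1cccc(-n2cc(-c3ccncc3)c(-c3ccc(Cl)c(O)c3)n2)c1)Nc1cccc(C(F)(F)F)c1`, with 7350 nM, sits beyond it. Compound 4 `O=C(Nc1cccc(-n2cc(-c3ccncc3)c(-c3ccc(Cl)c(O)c3)n2)c1)Nc1ccc(Cl)c(C(F)(F)F)c1` differs from compound 3 by hydrogen in place of methyl on an oxygen on an aromatic ring. For the measured compounds named here, the only measured step, a 4.9-fold lower number from compound 1 to compound 2 (0.69 log units; beyond the scatter), concerns a different place on the shared core, so no measured step bears on the present change; compounds 1 and 2 do carry the hydroxy group, but their numbers speak only of that other change. Without a guide, compound 4 is expected to show a 1.0-fold lower number from compound 3 to compound 4 (0.00 log units; within the scatter), no step beyond the scatter. The estimate for compound 4 is 1800 nM, between 600 nM and 5500 nM.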

Compound 4, concentration for 50% growth inhibition: 1350 nM
For compound 4 the middle estimate is 1.3-fold (0.12 log units) above the measured one; the measured number falls inside the stated range.
By their numbers in this assay, from the lowest: compounds 4, 2 and 3 (each within the scatter of the next); then compound 1.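

In this assay, the change from methoxy to hydroxy gives a 1.3-fold lower number from compound 3 to compound 4 (0.13 log units; within the scatter), so with this substitution pattern on the other phenyl ring, the two groups cannot be told apart at this position. Elsewhere, trifluoromethyl in place of chloro gives a 1.1-fold lower number from compound 2 to compound 4 (0.05 log units; within the scatter), while chloro in place of hydrogen on an aromatic carbon gives a 5.4-fold lower number from compound 1 to compound 4 (0.74 log units; beyond the scatter), so the added chloro carries the one step beyond the scatter. No measured evidence accounts for these steps. The compounds shown leave open how a longer chain on that oxygen, such as ethoxy, or an amine in place of the hydroxy would behave.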